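From a 4-Methylphenyl Amide to a Morpholin-4-yl Amide

This account rests on a few compounds, and the source may have more. Where it says the series, first, only, none or still open, it means among the compounds named here.

In a functional assay on the whole organism (strain Kunming) for inhibition, with Mus musculus as the target, in the writhing test, at a dose of 40 mg/kg by the oral route (a higher number here means more inhibition at the dose given (going by the name of the read-out), a lower number less inhibition), three compounds have been measured:
compound 1, `CC(=O)Oc1ccc(-c2ccc(F)cc2F)cc1C(=O)O`, gives 0%;
compound 2, `CC(=O)Oc1ccc(-c2ccc(F)cc2F)cc1C(=O)NC1CCCCC1`, gives 15.6%;
compound 3, `CC(=O)Oc1ccc(-c2ccc(F)cc2F)cc1C(=O)Nc1ccc(C)cc1`, gives 31%.

Compound 3 stands highest of the three: the step is a number 15.4 percentage points higher from compound 2 to compound 3 (beyond the scatter) and a number 31 percentage points higher from compound 1 to compound 3 (beyond the scatter). Compound 4, `CC(=O)Oc1ccc(-c2ccc(F)cc2F)cc1C(=O)NN1CCOCC1`, differs from compound 3 by morpholin-4-yl in place of 4-methylphenyl on an amide-type nitrogen. The step that bears on this is a number 15.4 percentage points higher from compound 2 to compound 3 (beyond the scatter), a modest gain when an aromatic ring replaced a non-aromatic one on that nitrogen; here a non-aromatic ring enters again. Within the data shown here, no measured pair shows a morpholin-4-yl. A modest fall is therefore expected, a number 16 percentage points lower from compound 3 to compound 4 (beyond the scatter), and compound 4 is estimated at 15%, between 0% and 35%.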

Compound 4, a percentage reported as inhibition, in the whole organism at one dose (the size of the read-out at that dose, not a potency): 28.5%
Beside the measured number, compound 4's estimate is 13.5 percentage points below it; low and high end bracket the measured number.
By their numbers in this assay, from the lowest: compound 1; then compound 2; then compounds 4 and 3 (each within the scatter of the next).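

Morpholin-4-yl in place of 4-methylphenyl gives a number 2.5 percentage points lower from compound 3 to compound 4 (within the scatter), so an aromatic ring on this amide-type nitrogen is not required for this level of inhibition. Not every non-aromatic ring reaches that level, though: morpholin-4-yl in place of cyclohexyl gives a number 12.9 percentage points higher from compound 2 to compound 4 (beyond the scatter), and (morpholin-4-yl)amino in place of hydroxy gives a number 28.5 percentage points higher from compound 1 to compound 4 (beyond the scatter). No evidence here explains why the two non-aromatic rings differ.

As far as these compounds go, it remains open whether piperidin-1-yl, which has no ring oxygen, or open-chain dimethylamino on the same nitrogen would hold this level.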